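From Compound 2 to Compound 4: Chloro for Trifluoromethyl

The compounds below may be only part of what the source reports. "The series", "measured", "known", "first", "only" and "open" are said of these compounds alone.

Compound 1 `O=C1CCC(O)(c2cccc(C(F)(F)F)c2)N1` — in a functional assay on the whole organism with Mus musculus as the target (on this read-out higher numbers stand for an effect only at larger amounts of compound and lower numbers for an effect already at smaller amounts), compound 1 gives > 200 mg/kg, which is a limit of the assay rather than a number.
Compound 2 `CN1C(=O)CCC1(O)c1cccc(C(F)(F)F)c1` — in this assay compound 2 gives 133 mg/kg.
Compound 3 `CCCN1C(=O)CCC1(O)c1cccc(C(F)(F)F)c1` — in this assay compound 3 gives 200 mg/kg.

Compound 2 holds the lowest of the two numbers. Its nearest neighbour, compound 3, is separated by a 1.5-fold higher number from compound 2 to compound 3 (0.18 log units; within the scatter), within the scatter. Compound 1 stands at the limit of > 200 mg/kg in this assay, at which 1 of the 3 values shown sits. Compound 4 `CN1C(=O)CCC1(O)c1cccc(Cl)c1` differs from compound 2 by chloro in place of trifluoromethyl on an aromatic carbon. All measured steps, an at least 1.5-fold lower number from compound 1 to compound 2 (0.17 log units; that floor lies within the scatter), a number no higher from compound 1 to compound 3 (the limit leaves the size open) and a 1.5-fold higher number from compound 2 to compound 3 (0.18 log units; within the scatter), alter the group on the amide-type nitrogen, and none touches the aromatic ring, so they offer no direct guide. Without any measured step on the aromatic carbon, the expected change is no change at the digits printed from compound 2 to compound 4 (within the scatter), nothing beyond the scatter. Compound 4 is therefore estimated at 133 mg/kg, between 60 mg/kg and 300 mg/kg.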

Compound 4, dose for half-maximal effect: > 200 mg/kg
Compound 4 was reported as a limit (the forecaster's own chance of this, stated with the estimate: 25%); at least 1.5-fold (0.17 log units) between middle value and limit.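

For the compounds shown here, this is the first step on an aromatic carbon, as all earlier steps altered the group on the amide-type nitrogen. In this assay, from the compounds shown here alone, the swap reads as an at least 1.5-fold higher number from compound 2 to compound 4 (0.17 log units; that floor lies within the scatter), so chloro in place of trifluoromethyl gives no lower number here, but the size of the step stays open. Compound 4 gives a limit of the assay rather than a number, as compound 1 does: the limit of > 200 mg/kg in this assay, at which 2 of the 4 values shown sit.

The compounds shown leave open how far compound 4 truly lies from compound 2. They also leave open what a methoxy group or an amine on this aromatic carbon would give.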